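From cyclopropyl to oxan-4-yl on the carbonyl

This account rests on a few compounds, and the source may have more. Where it says the series, first, only, none or still open, it means among the compounds named here.

Measured in an ADME assay on the whole organism (Rattus norvegicus, strain Wistar Han) for pharmacokinetics, at a dose of 0.05 mg/kg; on this read-out higher numbers stand for fast clearance and lower numbers for slow clearance:
- compound 1 `CCC(=O)N1CC[C@H](Nc2ncnc3c2nc(-c2cnn(CC)c2C)n3C)C1`: 58 mL/min/kg
- compound 2 `CCn1ncc(-c2nc3c(N[C@H]4CCN(C(=O)C5CC5)C4)ncnc3n2C)c1C`: 49 mL/min/kg

Compound 2 stands at 49 mL/min/kg, within the scatter of compound 1, so the two cannot be ranked. Compound 3 `CCn1ncc(-c2nc3c(N[C@H]4CCN(C(=O)C5CCOCC5)C4)ncnc3n2C)c1C` carries oxan-4-yl in place of cyclopropyl on a carbonyl carbon. Among the measured compounds shown here, the only measured step at this place is a 1.2-fold lower number from compound 1 to compound 2 (0.07 log units; within the scatter), with cyclopropyl in place of ethyl on a carbonyl carbon. For the measured compounds named here, that step stayed within the scatter, but no measured compound has a six-membered ring here, so it offers only weak guidance for oxan-4-yl. No step beyond the scatter is therefore expected in this assay. The estimated change is a 1.1-fold lower number from compound 2 to compound 3 (0.04 log units; within the scatter). For compound 3 the expected clearance is 45 mL/min/kg, with an estimated range of 25 mL/min/kg to 75 mL/min/kg.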

Compound 3, clearance: 95 mL/min/kg
The estimate for compound 3 lay 2.1-fold (0.32 log units) below the measured number, and the stated range ends below it.
By their numbers in this assay, from the lowest: compounds 2, 1 and 3 (each within the scatter of the next).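

In this assay, the step of a 1.9-fold higher number from compound 2 to compound 3 (0.29 log units; within the scatter) shows that even the larger oxan-4-yl ring, with its 6 heavy atoms and 1 hydrogen-bond acceptor, does not move the number beyond the scatter. Among the compounds shown here, the step of a 1.6-fold higher number from compound 1 to compound 3 (0.21 log units; within the scatter) gives the same reading against ethyl, so on this carbonyl carbon ethyl, cyclopropyl and oxan-4-yl cannot be ranked, although these two steps are larger than the one printed between the earlier compounds. Nothing available explains the numbers of these compounds.

The compounds shown do not separate ring size from the ring oxygen, since cyclohexyl, the all-carbon six-membered ring, is not among them. They also leave open whether an amine such as piperidin-4-yl, or a carboxylic acid, at this place would give a step beyond the scatter.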